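A piperidine in place of a pyridinyl thioether

A few compounds are considered here, and "the series" means these few. Any claim that something is new, unique, unknown or untested is made for them only; others in the source may bear on it.

Compound 1 `CC1(C)Cc2cc(N)ccc2O1` reaches the limit of a functional assay on the whole organism with Mus musculus as the target (a higher number here means that more compound is needed for the effect, a lower number that less compound is needed), recorded as > 100 mg/kg. Within the data shown here, compound 2 `Cc1c(C)c2c(c(C)c1N)CC(C)(CSc1ccncc1)O2` gives 19.9 mg/kg in this assay, the only number among the values shown. The other value shown is the limit of > 100 mg/kg in this assay, at which 1 of the 2 values shown sits. Compound 3 `Cc1c(C)c2c(c(C)c1N)CC(C)(CCN1CCCCC1)O2` differs from compound 2 by (piperidin-1-yl)methyl in place of (pyridin-4-yl)sulfanyl on a saturated chain carbon bound to a saturated ring carbon. Among the measured compounds shown here, no measured step covers a change of this kind, so no step beyond the scatter is expected in this assay in either direction. Compound 3 is expected to give about 20 mg/kg, between 7 mg/kg and 60 mg/kg, in this assay. The step of a 1.0-fold higher number from compound 2 to compound 3 (0.00 log units; within the scatter) that this estimate implies is expected to stay within the scatter.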

Compound 3, dose for 50% inhibition: 18.4 mg/kg
Estimate against measurement, compound 3: 1.1-fold (0.04 log units) above; low and high end bracket the measured number.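

In this assay, among these compounds, the first step at this place, on a saturated chain carbon bound to a saturated ring carbon, is a 1.1-fold lower number from compound 2 to compound 3 (0.03 log units; within the scatter). An aromatic ring with a sulfur link and a non-aromatic ring with a carbon link are thus interchangeable here in this read-out, with the nitrogen-bearing six-membered ring kept in both. Nothing shown accounts for this outcome.

As far as these compounds go, what remains open is whether a six-membered ring is needed at this place at all. An open-chain amine such as dimethylamino, or a carboxylic acid, could answer that.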